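Ester Variation and Microsomal Half-Life of a Shared Core

The source may hold more compounds than are shown below. What is called first, only, known or untested is meant among the compounds shown, and "the series" means these compounds.

compound 1, `CCOc1cc(NC(=O)C2(NC(=O)c3ccc4c(C5CCCC5)c(-c5ncc(Cl)cn5)n(C)c4c3)CCC2)ccc1/C=C/C(=O)OC(=O)C[C@H](O)C(=O)O`: 7.92 h
compound 2, `CCOC(=O)/C=C/c1ccc(NC(=O)C2(NC(=O)c3ccc4c(C5CCCC5)c(-c5ncc(Cl)cn5)n(C)c4c3)CCC2)cc1OCC`: 3.07 h
compound 3, `CCOc1cc(NC(=O)C2(NC(=O)c3ccc4c(C5CCCC5)c(-c5ncc(Cl)cn5)n(C)c4c3)CCC2)ccc1/C=C/C(=O)OCC(Cl)(Cl)Cl`: 0.233 h

In an ADME assay (liver) for pharmacokinetics, with Liver microsome (Rattus norvegicus) as the target, using microsomes (a lower number here means that the compound disappears faster, a higher number that the compound lasts longer), compound 3 gives the lowest number of the three. The step of a 13-fold lower number from compound 2 to compound 3 (1.12 log units; beyond the scatter) and the step of a 34-fold lower number from compound 1 to compound 3 (1.53 log units; beyond the scatter) both lie beyond the scatter, so compound 3 stands clearly below the other two measured compounds. Compound 4, `CCOc1cc(NC(=O)C2(NC(=O)c3ccc4c(C5CCCC5)c(-c5ncc(Cl)cn5)n(C)c4c3)CCC2)ccc1/C=C/C(=O)OCC(=O)OCc1ccc(Cl)cc1`, differs from compound 3 in one place: ((4-chlorobenzyl)oxy)carbonyl in place of trichloromethyl on a saturated chain carbon bound to an oxygen next to a carbonyl group. The step that bears most directly on this change is a 13-fold lower number from compound 2 to compound 3 (1.12 log units; beyond the scatter), in which the trichloromethyl group entered and the number fell sharply; compound 4 removes that group again, but puts a ((4-chlorobenzyl)oxy)carbonyl group in its place rather than returning to compound 2. The step of a 2.6-fold lower number from compound 1 to compound 2 (0.41 log units; beyond the scatter) shows that exchanging what sits on the oxygen next to the carbonyl group can also shift the number by a modest amount on its own. Compound 4 is therefore expected to show a step of a 6.4-fold higher number from compound 3 to compound 4 (0.81 log units; beyond the scatter), placing it well above compound 3 yet not clearly above compound 2. The estimate for compound 4 in this assay is 1.5 h, with a range from 0.4 h to 5 h.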

Compound 4, half-life: 11.4 h
For compound 4 the middle estimate is 7.6-fold (0.88 log units) below the measured one; the measured number lies above the stated range.
By their numbers in this assay, from the lowest: compound 3; then compound 2; then compounds 1 and 4 (each within the scatter of the next).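

In this assay the change from trichloromethyl to ((4-chlorobenzyl)oxy)carbonyl on a saturated chain carbon bound to an oxygen next to a carbonyl group gives a 49-fold higher number from compound 3 to compound 4 (1.69 log units; beyond the scatter) and so does more than undo the earlier fall, since the comparison with the ethyl group gives a 3.7-fold higher number from compound 2 to compound 4 (0.57 log units; beyond the scatter) as well. The earlier compounds had left the longest half-life with the carboxy- and hydroxy-bearing group of compound 1, but the comparison that gives a 1.4-fold higher number from compound 1 to compound 4 (0.16 log units; within the scatter) lies within the scatter, so among these compounds a group with no net charge and a six-membered aromatic ring serves as well as that one. Nothing available explains why the half-life responds to this position as it does.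

The compounds shown do not separate the part played by the chain carbonyl from that of the 4-chlorobenzyl ring, so a simple methyl group on that carbonyl oxygen or an unsubstituted benzyl group would be needed to tell them apart. From the compounds shown here alone, it also remains open whether a free carboxylic acid on the same chain carbon would keep the number at this level.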